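The source may hold more compounds than are shown below. What is called first, only, known or untested is meant among the compounds shown, and "the series" means these compounds.

In an ADME assay on L02 cells (Homo sapiens) for cytotoxicity, read by MTT assay, with a stated time of 48 h (a higher number here means a weaker inhibitor, a lower number a stronger inhibitor), compound 1 `O=C1O[C@@H](CO)CN1c1ccc(-n2cc(-c3ccccn3)cn2)c(F)c1` gives 59 ug/mL. Compound 2 `O=C(OC[C@H]1CN(c2ccc(-n3cc(-c4ccccn4)cn3)c(F)c2)C(=O)O1)c1ccccc1` reaches only the limit of this assay, at > 400 ug/mL. Compound 3 `O=CNC[C@H]1CN(c2ccc(-n3cc(-c4ccccn4)cn3)c(F)c2)C(=O)O1` likewise stands at a limit of this assay, at > 400 ug/mL. Compound 3 thus sits at the limit of > 400 ug/mL in this assay, at which 2 of the 3 values shown sit, so its position among the three values shown is known only as a limit. Compound 4 `NC(=O)[C@H]1CN(c2ccc(-n3cc(-c4ccccn4)cn3)c(F)c2)C(=O)O1` differs from compound 3 by carbamoyl in place of (formylamino)methyl on a saturated ring carbon. Among the compounds with values here, no measured step changes this ring carbon's substituent in the same way; the nearest evidence is the step of an at least 6.7-fold higher number from compound 1 to compound 3 (0.83 log units; beyond the scatter), and the step that the two limits leave unreadable from compound 2 to compound 3. Both suggest that the groups at this end of the molecule move the number only weakly or leave it at the limit. For compound 4 a step of an at least 1.3-fold lower number from compound 3 to compound 4 (0.12 log units; that floor lies within the scatter) is therefore expected, with a sizable chance that this assay again reports only a limit. Compound 4 is estimated at 300 ug/mL, within 100 ug/mL to 800 ug/mL.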

Compound 4, half-maximal inhibitory concentration: 119 ug/mL
Compound 4: middle estimate off by 2.5-fold (0.40 log units), on the high side; measured number inside the range.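

In this assay, carbamoyl on the saturated ring carbon gives a number clear of the limit, with an at least 3.3-fold lower number from compound 3 to compound 4 (0.52 log units; beyond the scatter) and an at least 3.3-fold lower number from compound 2 to compound 4 (0.52 log units; beyond the scatter). Both steps are floors whose full size cannot be read, as compound 2 and compound 3 each stand at a limit: the limit of > 400 ug/mL in this assay, at which 2 of the 4 values shown sit. Set against hydroxymethyl, carbamoyl shows a 2.0-fold higher number from compound 1 to compound 4 (0.30 log units; within the scatter), so a readable number at this position is no longer tied to hydroxymethyl alone, and a group carrying nitrogen can give one while (formylamino)methyl does not.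

The compounds shown do not tell whether an aminomethyl group, a carboxylic acid or a longer chain on this ring carbon would give a readable number or stand at the limit. They also leave open whether carbamoyl would behave the same way on a different core.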